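The source may report more compounds than this note shows. Statements on the series, on what has been measured and on what is new or still open speak of the compounds shown alone.

Notes on the series. Compound 1 `CC(=O)Nc1ccc(-n2nncc2CN2C(=O)C3(C(C#N)=C(N)Oc4c(N)cc5nc6ccccc6nc5c43)c3ccccc32)cc1` and compound 2 `N#CC1=C(N)Oc2c(N)cc3nc4ccccc4nc3c2C12C(=O)N(Cc1cnnn1-c1ccc([N+](=O)[O-])cc1)c1ccccc12` share one core and differ in a single place, nitro in place of acetamido on an aromatic carbon. In an ADME assay on L02 cells (Homo sapiens) for antiproliferative activity, read by MTT assay, with a stated time of 48 h (a higher number here means a weaker inhibitor, a lower number a stronger inhibitor), compound 1 gives > 50000 nM, which is a limit of the assay and not a number. In this assay compound 2 likewise gives > 50000 nM, again a limit of the assay. The step that the two limits leave unreadable from compound 1 to compound 2 cannot be sized, since the limit of > 50000 nM in this assay, at which 2 of the 2 values shown sit, holds both values. Compound 2 thus stands at the limit in this assay, with no measured number to place it further.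

Compound 3 `Cc1cc(C)cc(-n2nncc2CN2C(=O)C3(C(C#N)=C(N)Oc4c(N)cc5nc6ccccc6nc5c43)c3ccccc32)c1` differs from compound 2 by 3,5-dimethylphenyl in place of 4-nitrophenyl on an aromatic nitrogen, in words 3,5-dimethylphenyl in place of 4-nitrophenyl on an aromatic nitrogen. Among the compounds with values here, the only measured step, from compound 1 to compound 2, is unreadable in size and so neither supports nor rules out a shift in this assay. With both measured compounds sitting at the limit, compound 3 is expected to remain there, and the expected step is a step that the limit leaves unreadable from compound 2 to compound 3. Compound 3 is estimated at 60000 nM, within a range from 30000 nM to 200000 nM, most probably again reported as a limit only.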

Compound 3, half-maximal inhibitory concentration: > 50000 nM
Compound 3: only a limit was reported (the forecaster's own chance of this, stated with the estimate: 80%); the middle value is on the limit's open side.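

In this assay compound 3 gives > 50000 nM as a limit of the assay and not a number. Within the data shown here, no step among compound 1, compound 2 and compound 3 can be read, and all three sit together: the limit of > 50000 nM in this assay, at which 3 of the 3 values shown sit. The compounds shown leave open how far each lies beyond that limit and whether the group on the aromatic nitrogen has any bearing on the result in this assay at all.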